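A dihydroxypropyl amide in place of the methylsulfonyl chain

A few compounds are considered here, and "the series" means these few. Any claim that something is new, unique, unknown or untested is made for them only; others in the source may bear on it.

In a functional assay on MDA-MB-231 cells (Homo sapiens) for antiproliferative activity, read by MTT assay, with a stated time of 48 h (a lower number here means a stronger inhibitor, a higher number a weaker inhibitor), compound 1 (`Cc1c(C(=O)NCCCN(C)C)oc2ccc(N(Cc3ccc(Br)cc3)S(=O)(=O)c3ccc(Br)cc3)cc12`) gives 6680 nM. Compound 2 (`Cc1c(C(=O)OCCCN(C)C)oc2ccc(N(Cc3ccc(Br)cc3)S(=O)(=O)c3ccc(Br)cc3)cc12`), the ester counterpart, gives 28600 nM, and the measured change is a 4.3-fold higher number from compound 1 to compound 2 (0.63 log units; beyond the scatter).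

Compound 3 (`Cc1c(C(=O)NCCS(C)(=O)=O)oc2ccc(N(Cc3ccc(Br)cc3)S(=O)(=O)c3ccc(Br)cc3)cc12`) gives > 40000 nM, which is a limit of the assay and not a number.

The steps leading to this limit are an at least 5.9-fold higher number from compound 1 to compound 3 (0.77 log units; beyond the scatter) and an at least 1.3-fold higher number from compound 2 to compound 3 (0.14 log units; that floor lies within the scatter). Compound 4 (`Cc1c(C(=O)NCC(O)CO)oc2ccc(N(Cc3ccc(Br)cc3)S(=O)(=O)c3ccc(Br)cc3)cc12`) keeps the shared core and the amide but carries (2,3-dihydroxypropyl)carbamoyl in place of (2-(methylsulfonyl)ethyl)carbamoyl: 1,2-dihydroxyethyl in place of (methylsulfonyl)methyl on a saturated chain carbon bound to an amide-type nitrogen.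

For the measured compounds named here, no measured step makes this exchange directly. The nearest guide is an at least 5.9-fold higher number from compound 1 to compound 3 (0.77 log units; beyond the scatter), which removed the dimethylamino group. Compound 4 lacks that group too, so it is expected to stay close to compound 3 in this assay, with no change beyond the scatter. The estimated step is an at least 1.1-fold lower number from compound 3 to compound 4 (0.05 log units; that floor lies within the scatter). The estimated value for compound 4 is 35000 nM, with an expected range of 14000 nM to 80000 nM.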

Compound 4, half-maximal inhibitory concentration: 16500 nM
Estimate against measurement, compound 4: 2.1-fold (0.33 log units) above, and the stated range covers the measured number.
By their numbers in this assay, from the lowest: compound 1; then compounds 4 and 2 (each within the scatter of the next). At a limit, above all of these: compound 3.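

Without the dimethylamino group, a chain at this place need not end at the assay limit: 1,2-dihydroxyethyl in place of (methylsulfonyl)methyl gives an at least 2.4-fold lower number from compound 3 to compound 4 (0.38 log units; beyond the scatter), so losing that amine does not settle the outcome alone. The dimethylamino chain still keeps an edge over the 2,3-dihydroxypropyl chain, with a 2.5-fold higher number from compound 1 to compound 4 (0.39 log units; beyond the scatter), while the 2,3-dihydroxypropyl amide and the 3-(dimethylamino)propyl ester stay within the scatter of each other, with a 1.7-fold lower number from compound 2 to compound 4 (0.24 log units; within the scatter). The value of compound 3 is a limit of the assay and not a number: the limit of > 40000 nM in this assay, at which 1 of the 4 values shown sits.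

The compounds shown leave open whether a single hydroxyl, as in a 2-hydroxyethyl amide, would do the same as the two in compound 4. They also leave open whether a carboxylic acid or a morpholine at the chain end would track the 2,3-dihydroxypropyl chain or the dimethylamino chain.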